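The source may hold more compounds than are shown below. What is called first, only, known or untested is meant among the compounds shown, and "the series" means these compounds.

Of the compounds shown here, three sharing one core have been measured in an ADME assay on SH-SY5Y cells (Homo sapiens) for cytotoxicity, read by MTT assay, with a stated time of 24 h, tested at 25 uM; on this read-out lower numbers stand for a stronger effect and higher numbers for a weaker effect at the one concentration tested. Compound 1 `COc1cc2c(cc1O)CCC(C)(CC(=O)O)O2` gives 92.5%. Compound 2 `COc1cc2c(cc1O)CCC(C)(CC(N)=O)O2` gives 100%, and the step of a number 7.5 percentage points higher from compound 1 to compound 2 (within the scatter) stays within the usual scatter, so these two cannot be told apart. Compound 3 `COc1cc2c(cc1O)CCC(C)(CCNC(C)=O)O2` gives 76.2%, the lowest of the three numbers; the steps of a number 16.3 percentage points lower from compound 1 to compound 3 (beyond the scatter) and a number 23.8 percentage points lower from compound 2 to compound 3 (beyond the scatter) both go beyond the scatter, so compound 3 shows the strongest effect among the three.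

Compound 4 `COc1cc2c(cc1O)CCC(C)(CC(N)C(=O)O)O2` differs from compound 3 in one place: amino(carboxy)methyl in place of acetamidomethyl on a saturated chain carbon bound to a saturated ring carbon. The measured steps that bear on this change are the two leading into compound 3, a number 16.3 percentage points lower from compound 1 to compound 3 (beyond the scatter) and a number 23.8 percentage points lower from compound 2 to compound 3 (beyond the scatter), each a modest drop when carboxy or carbamoyl gave way to acetamidomethyl. Compound 4 carries a carboxy group once more in the chain, and part of that drop is expected to turn back, giving an upward step of a number 11.8 percentage points higher from compound 3 to compound 4 (beyond the scatter). The estimated value for compound 4 in this assay is 88%, with a range from 72% to 100%.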

Compound 4, a percentage reported as activity, at one concentration (the size of the read-out at that concentration, not a potency): 88.5%
Compound 4: the middle estimate sits 0.5 percentage points below what was measured; the range from low to high includes it.
By their numbers in this assay, from the lowest: compound 3; then compounds 4, 1 and 2 (each within the scatter of the next, the first and the last beyond it).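

In this assay, this position tolerates a chain bearing an amino and a carboxy group together: amino(carboxy)methyl in place of acetamidomethyl gives a number 12.3 percentage points higher from compound 3 to compound 4 (beyond the scatter), so the stronger effect seen with acetamidomethyl does not extend to every nitrogen-bearing chain. Adding the amino group to the carboxy-bearing chain gives a number 4 percentage points lower from compound 1 to compound 4 (within the scatter), which leaves that pair indistinguishable, whereas a number 11.5 percentage points lower from compound 2 to compound 4 (beyond the scatter) marks a real separation from the carbamoyl compound. Nothing available explains these differences.

Open, as far as these compounds go, is which feature of acetamidomethyl goes with the stronger effect, and a plain 2-aminoethyl chain would test whether the amine alone matches it. The 2-acetamido-2-carboxyethyl group, which keeps the acetamide alongside the carboxylic acid, and a longer chain also remain to be compared at this position.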